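Changing the amide side chain of compound 2

The source may hold more compounds than are shown below. What is called first, only, known or untested is meant among the compounds shown, and "the series" means these compounds.

In a functional assay on HepG2 cells (Homo sapiens), read by MTT assay, with a stated time of 48 h (on this read-out lower numbers stand for stronger inhibition and higher numbers for weaker inhibition), compound 1 (`CCn1c(C(=O)NCCN)ccc1C(CC)(CC)c1ccc(OCC(=O)C(C)(C)C)c(C)c1`) gives 180 nM, and compound 2 (`CC[C@@H](C)[C@H](NC(=O)c1ccc(C(CC)(CC)c2ccc(OCC(=O)C(C)(C)C)c(C)c2)n1CC)C(=O)O`) gives 247 nM, so the two values lie within the usual scatter of each other. Compound 3 (`CCn1c(C(=O)N(C)CC(=O)O)ccc1C(CC)(CC)c1ccc(OCC(=O)C(C)(C)C)c(C)c1`) alters the group on the carbonyl carbon of compound 2: (carboxymethyl)(methyl)amino in place of (1-carboxy-2-methylbutyl)amino on a carbonyl carbon. Among the compounds with values here, the only measured step, a 1.4-fold higher number from compound 1 to compound 2 (0.14 log units; within the scatter), changed this same side chain, so no step beyond the scatter is expected in this assay. Within the data shown here, no measured compound carries the methyl group on that amide nitrogen, so the range stays wide. The estimated step is a 1.1-fold higher number from compound 2 to compound 3 (0.02 log units; within the scatter). For compound 3 the expected value is 260 nM, with an estimated range of 100 nM to 700 nM.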

Compound 3, half-maximal inhibitory concentration: 25200 nM
For compound 3 the middle estimate is 97-fold (1.99 log units) below the measured one, and the stated range ends below it.
By their numbers in this assay, from the lowest: compounds 1 and 2 (each within the scatter of the next); then compound 3.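

The side chain on this carbonyl carbon is less forgiving than compound 1 and compound 2 suggested, since their two different chains stayed within the scatter. In this assay, (carboxymethyl)(methyl)amino brings a 100-fold higher number from compound 2 to compound 3 (2.01 log units; beyond the scatter) and a 140-fold higher number from compound 1 to compound 3 (2.15 log units; beyond the scatter). Nothing measured here explains this loss.

The change combines a methyl group on the amide nitrogen with a shorter chain, and the compounds shown do not separate the two. A compound with (carboxymethyl)amino, which keeps the amide hydrogen, would test the methyl group alone.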